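This account rests on a few compounds, and the source may have more. Where it says the series, first, only, none or still open, it means among the compounds named here.

Compound 1, `COC(=O)C1=C(C)N=C(C)/C(=C(\O)OC)C1c1cccc(N(C)C)c1`, is the starting point of the step followed here. Among the measured compounds shown here, in a functional assay (muscle tissue) with Cavia porcellus as the target (a higher number here means that more compound is needed for the effect, a lower number that less compound is needed), compound 1 gives 891 nM, the highest of the three numbers measured so far, so of these three it needs the most compound for the effect. Compound 2, `CCOc1ccccc1C1C(C(=O)OC)=C(C)N=C(C)/C1=C(\O)OC`, gives 110 nM in this assay, a lower number that lies beyond the scatter of repeated measurements. Compound 3, `COC(=O)C1=C(C)N=C(C)/C(=C(\O)OC)C1c1cc([N+](=O)[O-])ccc1Cl`, gives 30.2 nM in this assay, the lowest of the three and again beyond the scatter from compound 1. Compounds 2 and 3 each differ from compound 1 in more than one place, so their numbers only show that other groups on the shared core can bring the number down considerably.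

The step to compound 4, `COC(=O)C1=C(C)N=C(C)/C(=C(\O)OC)C1c1cccc(OC(=O)c2ccccc2)c1`, changes a single place: benzoyloxy in place of dimethylamino on an aromatic carbon. The group that leaves is small, the group that enters is larger and brings a second aromatic ring with it. For the measured compounds named here, no measured pair shows this exact change, so the size of the step can only be judged from the other numbers. A step in the same downward direction is expected here, of moderate size, as a 3.6-fold lower number from compound 1 to compound 4 (0.55 log units; beyond the scatter). The value expected for compound 4 in this assay is 250 nM, within a range from 60 nM to 1000 nM.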

Compound 4, half-maximal effective concentration: 6310 nM
The estimate for compound 4 lay 25-fold (1.40 log units) below the measured number; the whole stated range lies below it.
By their numbers in this assay, from the lowest: compound 3; then compound 2; then compound 1; then compound 4.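

Putting benzoyloxy in place of dimethylamino gives a 7.1-fold higher number from compound 1 to compound 4 (0.85 log units; beyond the scatter) in this assay and is the only step shown so far that changes a single place on the shared core. At this aromatic carbon, meta to a large group, the larger group with its second aromatic ring therefore goes with more compound being needed for the effect, although this rests on one pair alone. No measurement shown here separates the possible contributions of the added ring, the extra heavy atoms or the loss of the nitrogen, and nothing available accounts for the rise.

On these data alone, it remains open whether a small oxygen-linked group such as methoxy or acetyloxy would give a number closer to that of compound 1, which would show whether the oxygen link or the second ring matters more. Also open, as far as these compounds go, is whether a benzyl group or a plain phenyl ring, each carrying a second ring without the carbonyl, would raise the number in the same way.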